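From compound 3 to compound 4: the cyano group goes

This account rests on a few compounds, and the source may have more. Where it says the series, first, only, none or still open, it means among the compounds named here.

In a physicochemical assay for metabolic stability, read by HPLC (a lower number here means that the compound disappears faster, a higher number that the compound lasts longer), compound 1 `Cc1cn([C@H]2C[C@H](N=[N+]=[N-])[C@@H](COP(=O)(O)Oc3ccncc3)O2)c(=O)[nH]c1=O` gives a half-life of 8.07 h on the shared core, compound 2 `Cc1ccc(OP(=O)(O)OC[C@H]2O[C@@H](n3cc(C)c(=O)[nH]c3=O)C[C@@H]2N=[N+]=[N-])cn1` gives 28.9 h and compound 3 `Cc1cn([C@H]2C[C@H](N=[N+]=[N-])[C@@H](COP(=O)(O)Oc3ccc(C#N)cc3)O2)c(=O)[nH]c1=O` gives 7.08 h as its half-life. Compound 3 sits at the low end of this small set, level within the scatter with compound 1 and clearly under compound 2.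

Compound 4 `Cc1cn([C@H]2C[C@H](N=[N+]=[N-])[C@@H](COP(=O)(O)Oc3ccccc3)O2)c(=O)[nH]c1=O` differs from compound 3 as follows: hydrogen in place of cyano on an aromatic carbon (hydrogen in place of cyano on an aromatic carbon, so 4-cyanophenyl becomes phenyl).

Among the measured compounds shown here, no measured pair isolates this change. The nearest evidence comes from swaps of the whole group on that oxygen, which gave a 1.1-fold lower number from compound 1 to compound 3 (0.06 log units; within the scatter) in one case, but a 3.6-fold higher number from compound 1 to compound 2 (0.55 log units; beyond the scatter) and a 4.1-fold lower number from compound 2 to compound 3 (0.61 log units; beyond the scatter) in the two others. The direction rests only on compound 3 standing at 7.08 h at the low end, so upward is the likelier way, with little confidence. The expected step is a 1.8-fold higher number from compound 3 to compound 4 (0.26 log units; within the scatter) and could prove somewhat larger. Compound 4 is expected at 13 h (estimated range 6.5 h to 30 h) in this assay as its half-life.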

Compound 4, half-life: 9.47 h
For compound 4 the middle estimate is 1.4-fold (0.14 log units) above the measured one; low and high end bracket the measured number.
By their numbers in this assay, from the lowest: compounds 3, 1 and 4 (each within the scatter of the next); then compound 2.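

In this assay, hydrogen in place of cyano on the six-membered aromatic ring of carbon only, para to a large group, gives a 1.3-fold higher number from compound 3 to compound 4 (0.13 log units; within the scatter), so this change does not separate compound 3 from compound 4. Phenyl on the oxygen likewise stands level with pyridin-4-yl, with a 1.2-fold higher number from compound 1 to compound 4 (0.07 log units; within the scatter), whereas 6-methylpyridin-3-yl stays apart, with a 3.1-fold lower number from compound 2 to compound 4 (0.48 log units; beyond the scatter), which leaves compound 2 as the only one of the four that goes against a flat picture at this oxygen. Nothing available explains this pattern.

Going by these compounds, whether a pyridin-3-yl without its methyl group, or a methyl group on the phenyl ring, would reach the number of compound 2 stays open. So does the effect of an amine or a carboxylic acid in place of the hydrogen of compound 4.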